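Chloro in place of hydrogen on compound 3

This account rests on a few compounds, and the source may have more. Where it says the series, first, only, none or still open, it means among the compounds named here.

compound 1 (`COc1ccccc1/C=C/C(=O)c1c(O)cc2occc2c1OC`) : > 100000 nM (a limit)
compound 2 (`COc1c(C(=O)/C=C/c2ccc(Cl)cc2)c(O)c(Br)c2occc12`) : 4110 nM
compound 3 (`C=CCc1c(O)c(C(=O)/C=C/c2ccccc2)c(OC)c2ccoc12`) : 3010 nM

In a functional assay on HT-29 cells (Homo sapiens) for inhibition, with a stated time of 48 h (on this read-out higher numbers stand for weaker inhibition of growth and lower numbers for stronger inhibition of growth), compound 1 gives only a limit of > 100000 nM and no number. Compound 3 gives 3010 nM and compound 2 gives 4110 nM and these two numbers lie within the scatter of each other. Compound 3 therefore stands level with compound 2 on the numbers available.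

Compound 4 (`C=CCc1c(O)c(C(=O)/C=C/c2ccc(Cl)cc2)c(OC)c2ccoc12`) differs from compound 3 by chloro in place of hydrogen on an aromatic carbon, para to a large group, which reads as phenyl to 4-chlorophenyl (chloro in place of hydrogen on an aromatic carbon). For the measured compounds named here, no measured pair isolates this change. Compound 2 already carries 4-chlorophenyl on a differently substituted core and gives 4110 nM so no step beyond the scatter is expected in this assay. The estimated step is a 1.2-fold lower number from compound 3 to compound 4 (0.08 log units; within the scatter) and it stays within the scatter. For compound 4 the expected value is 2500 nM with 1000 nM to 7000 nM as the estimated range.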

Compound 4, concentration for 50% growth inhibition: 1890 nM
Estimate against measurement, compound 4: 1.3-fold (0.12 log units) above, within the range that was stated.
By their numbers in this assay, from the lowest: compounds 4, 3 and 2 (each within the scatter of the next, the first and the last beyond it). At a limit, above all of these: compound 1.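

In this assay, for the compounds shown here, the only measured pair at this position, phenyl to 4-chlorophenyl, gives a 1.6-fold lower number from compound 3 to compound 4 (0.20 log units; within the scatter), so chloro is accepted here and compound 3 and compound 4 stand level. With 4-chlorophenyl held constant, allyl in place of bromo on an aromatic carbon gives a 2.2-fold lower number from compound 2 to compound 4 (0.34 log units; beyond the scatter), a modest step and the only one shown beyond the scatter, which places it away from the 4-chlorophenyl ring. No value shown gives a cause for either step.

As far as these compounds go, whether a group other than chloro at this position, such as fluoro, an amine or a carboxylic acid, would give a step beyond the scatter stays open. Also open, from the compounds shown here alone, is whether a longer chain in place of allyl would keep the value of compound 4 at 1890 nM or shift it.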